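A few compounds are considered here, and "the series" means these few. Any claim that something is new, unique, unknown or untested is made for them only; others in the source may bear on it.

Compound 1 `Cc1ccc(-n2nncc2CN2C(=O)C3(C(C#N)=C(N)Oc4c3c3nc5ccccc5nc3c3ccccc43)c3ccccc32)cc1Cl` gives > 50000 nM in a functional assay on MCF7 cells (Homo sapiens) for antiproliferative activity, read by MTT assay, with a stated time of 48 h; on this read-out higher numbers stand for weaker inhibition and lower numbers for stronger inhibition; this is a limit of the assay and not a number.
Compound 2 `N#CC1=C(N)Oc2c(c3nc4ccccc4nc3c3ccccc23)C12C(=O)N(Cc1cnnn1-c1ccc(Cl)c(Cl)c1)c1ccccc12` gives > 50000 nM in this assay; this too is a limit.
Compound 3 `N#CC1=C(N)Oc2c(N)cc3nc4ccccc4nc3c2C12C(=O)N(Cc1cnnn1-c1ccc(F)cc1)c1ccccc12` gives > 50000 nM in this assay; this also is a limit.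

Compound 3 thus stands at the limit, and so do the other two measured compounds, as the limit of > 50000 nM in this assay, at which 3 of the 3 values shown sit, records. No numerical value is available for any of them. Within the data shown here, the only step between two measured compounds that differ in one place, a step that the two limits leave unreadable from compound 1 to compound 2, has both its ends at the limit and cannot be read in size or direction.

Compound 4 `Cc1ccc(C)c(-n2nncc2CN2C(=O)C3(C(C#N)=C(N)Oc4c(N)cc5nc6ccccc6nc5c43)c3ccccc32)c1` differs from compound 3 in one place: 2,5-dimethylphenyl in place of 4-fluorophenyl on an aromatic nitrogen. Among the measured compounds shown here, no measured step involves this kind of exchange, so the measured compounds give no guidance on the direction or size of the step in this assay. What they do show is that each one sits at the limit, and nothing suggests that compound 4 will depart from it.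

Compound 4 is therefore expected to stay at the limit, with an expected step that the limit leaves unreadable from compound 3 to compound 4 of no readable size. Compound 4 is estimated at 60000 nM, within a range from 15000 nM to 250000 nM, and most likely reported only as a limit.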

Compound 4, half-maximal inhibitory concentration: > 50000 nM
Compound 4 gave a limit, no number (the forecaster's own chance of this, stated with the estimate: 85%); the middle value is on the limit's open side.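

The step from compound 3 to compound 4, 2,5-dimethylphenyl in place of 4-fluorophenyl, cannot be read in size or direction, because both ends are limits and not numbers: the limit of > 50000 nM in this assay, at which 4 of the 4 values shown sit.

The compounds shown leave open whether any group on this shared core can bring a readable number in this assay.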